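Reshuffling Eight Carbons on a Weak Receptor Agonist

The compounds below may be only part of what the source reports. "The series", "measured", "known", "first", "only" and "open" are said of these compounds alone.

Compound 1 `CCc1ccccc1-c1cccc(COc2ccc([C@H](CC(=O)O)c3nccn3C)cc2)c1` was tested in an assay on CHO cells for agonist activity at Free fatty acid receptor 1 (Homo sapiens), read by luminescence, with a stated time of 20 s, in the presence of a further agent that is not named here (on this read-out higher numbers stand for an effect only at larger amounts of compound and lower numbers for an effect already at smaller amounts), where compound 1 gives 65000 nM, a weak effect that appears only at large amounts. For the measured compounds named here, compound 1 is the only member of this small set with a number at all: compound 2 `COc1ccccc1-c1cccc(COc2ccc([C@H](CC(=O)O)c3nccn3C)cc2)c1` gives "not determined" (no result reported) in this assay, and compound 3 `COc1ccc(-c2cccc(COc3ccc([C@H](CC(=O)O)c4nccn4C)cc3)c2)cc1` gives "not determined" (no result reported) in this assay, so neither of them, though they carry methoxy groups in place of the ethyl group, has a result recorded. Compound 4 `Cc1cccc(C)c1-c1cccc(COc2ccc([C@H](CC(=O)O)c3nccn3C)cc2)c1` is the next one to be measured. It differs from compound 1 in one place: 2,6-dimethylphenyl in place of 2-ethylphenyl on an aromatic carbon. The same atoms are present in both compounds, only joined differently, and the change sits on an aromatic carbon of a six-membered aromatic ring of carbon only, meta to a large group.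

Going by the values given here, no pair of measured compounds shows how a change at this position moves the read-out, so there is nothing to build a firm direction on. Rearranging eight carbons around the same ring is expected to leave the value close to that of compound 1, with an expected step from compound 1 to compound 4 of a 1.2-fold lower number from compound 1 to compound 4 (0.07 log units; within the scatter), inside the usual scatter. Compound 4 is therefore estimated at 55000 nM, with a range from 15000 nM to 200000 nM.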

Compound 4, half-maximal effective concentration: 29000 nM
For compound 4 the middle estimate is 1.9-fold (0.28 log units) above the measured one; low and high end bracket the measured number.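

The change to 2,6-dimethylphenyl in place of 2-ethylphenyl brings a 2.2-fold lower number from compound 1 to compound 4 (0.35 log units; beyond the scatter), a modest step but the first one that can be read at this position. It shows that in this assay the read-out responds to how the same atoms are arranged on this ring, even with no hydrogen-bond donor, hydrogen-bond acceptor or net charge gained or lost. Even so, compound 4 at 29000 nM still acts only at large amounts, and no measurement here explains the step.

This single pair cannot show whether the step belongs to the second methyl group, to the loss of the ethyl group or to both. It also leaves open how the read-out would respond to a different group on this ring, such as a chlorine atom, a trifluoromethyl group or an amine.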